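The source may report more compounds than this note shows. Statements on the series, on what has been measured and on what is new or still open speak of the compounds shown alone.

Values in a functional assay, read by spectrophotometry, with a stated time of 15 min (a higher number here means a weaker inhibitor, a lower number a stronger inhibitor), for the measured members of the series:

- compound 1 `Cc1nc2c3ccccc3ccc2c2nc3c(ccc4ccccc43)c(-c3cccnc3)c12`: 63.6 ug/mL
- compound 2 `Cc1nc2c3ccccc3ccc2c2nc3c(ccc4ccccc43)c(-c3ccccc3N)c12`: 45.6 ug/mL
- compound 3 `Cc1nc2c3ccccc3ccc2c2nc3c(ccc4ccccc43)c(-c3ccccc3Cl)c12`: 74.6 ug/mL

All three share one core and differ only in the aryl group attached to it. Compound 3 gives the largest of the three numbers, but a 1.2-fold higher number from compound 1 to compound 3 (0.07 log units; within the scatter) and a 1.6-fold higher number from compound 2 to compound 3 (0.21 log units; within the scatter) both fall within the scatter, so the three compounds are not separated by this assay.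

Compound 4 `Cc1nc2c3ccccc3ccc2c2nc3c(ccc4ccccc43)c(-c3ccccc3S)c12` is not yet measured. It differs from compound 3 by sulfanyl in place of chloro on an aromatic carbon. The step most comparable to this one is a 1.6-fold higher number from compound 2 to compound 3 (0.21 log units; within the scatter), which exchanged one small group for another on the same phenyl ring and stayed within the scatter; the broader exchange of the whole aryl group, a 1.2-fold higher number from compound 1 to compound 3 (0.07 log units; within the scatter), likewise stayed within the scatter. Among the measured compounds shown here, nothing among the measured steps points to a shift beyond the scatter in this assay for a further small exchange on that ring.

For compound 4 the expected step is therefore a 1.1-fold lower number from compound 3 to compound 4 (0.06 log units; within the scatter), within the scatter. The estimated value for compound 4 in this assay is 65 ug/mL, with a range of 32 ug/mL to 130 ug/mL.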

Compound 4, half-maximal inhibitory concentration: 49.6 ug/mL
The estimate for compound 4 lay 1.3-fold (0.12 log units) above the measured number; the range from low to high includes it.
By their numbers in this assay, from the lowest: compounds 2, 4, 1 and 3 (each within the scatter of the next).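

In this assay, sulfanyl can replace chloro on this phenyl ring, ortho to a large group, with only a 1.5-fold lower number from compound 3 to compound 4 (0.18 log units; within the scatter). Sulfanyl in place of amino gives a 1.1-fold higher number from compound 2 to compound 4 (0.04 log units; within the scatter), and 2-sulfanylphenyl in place of pyridin-3-yl gives a 1.3-fold lower number from compound 1 to compound 4 (0.11 log units; within the scatter), so a third small group on the ring also fails to separate from the others. Across chloro, amino, sulfanyl and the pyridin-3-yl exchange, every printed step at this position now lies within the scatter, and the series shows no order here.

No evidence is available that bears on why these values stay so close. From the compounds shown here alone, whether a carboxylic acid, a methoxy group or a longer alkyl chain on this ring would move the number beyond the scatter remains open.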